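The source may report more compounds than this note shows. Statements on the series, on what has been measured and on what is new or still open speak of the compounds shown alone.

Working notes on the series. The shared core of compound 1 `O=C(/C=C\Nc1ccc(O)cc1)c1cn(-c2ccccc2)nc1-c1ccccc1` carries a hydroxy on the aniline ring, and in an ADME assay on HaCaT cells (Homo sapiens) for antiproliferative activity, read by MTT assay, with a stated time of 48 h (on this read-out higher numbers stand for weaker inhibition and lower numbers for stronger inhibition), compound 1 gives 44600 nM. Compound 2 `O=C(/C=C\Nc1ccc(Cl)cc1)c1cn(-c2ccccc2)nc1-c1ccc(Cl)cc1` carries chloro on both outer rings; in this assay compound 2 gives 23400 nM. Compound 3 `O=C(/C=C\Nc1ccc(C(F)(F)F)cc1)c1cn(-c2ccccc2)nc1-c1ccc(Cl)cc1` keeps the chlorophenyl and puts trifluoromethyl on the aniline ring. For compound 3 this assay reports only a limit, > 50000 nM, so compound 3 stands at the weak end of the numbers shown, where (the limit of > 50000 nM in this assay, at which 1 of the 3 values shown sits). Among the compounds with values here, the one measured step with a single change is an at least 2.1-fold higher number from compound 2 to compound 3 (0.32 log units; beyond the scatter), which is at least modest and points toward weaker inhibition for trifluoromethyl.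

Compound 4 `O=C(/C=C\Nc1ccc(O)cc1)c1cn(-c2ccccc2)nc1-c1ccc(Cl)cc1` differs from compound 3 by hydroxy in place of trifluoromethyl on an aromatic carbon. Within the data shown here, no measured step covers this exchange directly; compound 1 with the same hydroxy gives 44600 nM and compound 2 gives 23400 nM, so compound 1 and compound 2 each return a measured number in this assay. Compound 4 is therefore expected to return a number rather than a limit, with a step of an at least 1.4-fold lower number from compound 3 to compound 4 (0.15 log units; that floor lies within the scatter) in this assay, at least modest toward stronger inhibition. The estimate for compound 4 is 35000 nM, with a range from 15000 nM to 70000 nM.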

Compound 4, half-maximal inhibitory concentration: 22600 nM
Compound 4: middle estimate off by 1.5-fold (0.19 log units), on the high side, and the stated range covers the measured number.
By their numbers in this assay, from the lowest: compounds 4, 2 and 1 (each within the scatter of the next). At a limit, above all of these: compound 3.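

With the chlorophenyl held fixed, hydroxy in place of trifluoromethyl on the aniline ring gives an at least 2.2-fold lower number from compound 3 to compound 4 (0.34 log units; beyond the scatter) in this assay, so this exchange at this position moves the read-out beyond the scatter. Hydroxy and chloro at the same place do not separate, with a 1.0-fold lower number from compound 2 to compound 4 (0.02 log units; within the scatter), which leaves trifluoromethyl as the one group of the three that stands apart among compound 2, compound 3 and compound 4. Chloro in place of hydrogen on an aromatic carbon gives a 2.0-fold lower number from compound 1 to compound 4 (0.30 log units; within the scatter), so this second change cannot be told from the scatter.

As far as these compounds go, compound 3 is still only a limit, and how far trifluoromethyl lies from hydroxy and chloro stays open: the limit of > 50000 nM in this assay, at which 1 of the 4 values shown sits. Whether an amine or a carboxylic acid at this place would read with hydroxy and chloro or with trifluoromethyl also stays open.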